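Glycosylated imide series: sugar truncation and cytotoxicity

A few compounds are considered here, and "the series" means these few. Any claim that something is new, unique, unknown or untested is made for them only; others in the source may bear on it.

Measured compounds:
compound 1, `O=C1NC(=O)c2c1c1c3ccccc3ccc1c1c2c2ccccc2n1[C@@H]1O[C@H](CO)[C@@H](O)[C@H](O)[C@H]1O`, 2700 nM
compound 2, `O=C1NC(=O)c2c1c1c3ccccc3ccc1c1c2c2ccccc2n1[C@@H]1O[C@H](CO)[C@@H](O)[C@H]1O`, 2400 nM

The two measured compounds share one core and differ only in the sugar on the aromatic nitrogen. In a functional assay on MDA-MB-231 cells (Homo sapiens) for cytotoxicity (a lower number here means a stronger inhibitor, a higher number a weaker inhibitor), compound 1 gives 2700 nM and compound 2 gives 2400 nM. Within the data shown here, the single measured step, a 1.1-fold lower number from compound 1 to compound 2 (0.05 log units; within the scatter), replaces one sugar by another and lands within the scatter, so the two values cannot be ordered; compound 2 holds the lower of the two numbers only nominally.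

Compound 3, `O=C1NC(=O)c2c1c1c3ccccc3ccc1c1c2c2ccccc2n1[C@H]1C[C@H](O)[C@@H](CO)O1`, takes the step from compound 2 one stage further: hydrogen in place of hydroxy on a saturated ring carbon. Among the measured compounds shown here, the only comparison that bears on it is the step from compound 1 to compound 2, which also removed a hydroxy-bearing part of the sugar and left the number unchanged within the scatter. On that basis no step beyond the scatter is expected in this assay: no change at the digits printed from compound 2 to compound 3 (within the scatter) is the expected change. The estimate for compound 3 is 2400 nM, with a range from 1000 nM to 5500 nM.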

Compound 3, half-maximal inhibitory concentration: 3300 nM
Compound 3: middle estimate off by 1.4-fold (0.14 log units), on the low side, within the range that was stated.
By their numbers in this assay, from the lowest: compounds 2, 1 and 3 (each within the scatter of the next).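

In this assay, taking away the hydroxy on the saturated ring carbon, next to the ring atom that bears the large group, gives a 1.4-fold higher number from compound 2 to compound 3 (0.14 log units; within the scatter), so the number of the sugar-bearing core does not respond measurably to this single change. The whole difference between the two ends of the set, 4-hydroxy-5-(hydroxymethyl)oxolan-2-yl in place of 3,4,5-trihydroxy-6-(hydroxymethyl)oxan-2-yl on the aromatic nitrogen, gives a 1.2-fold higher number from compound 1 to compound 3 (0.09 log units; within the scatter), so the two sugar changes taken together also stay inside the scatter and the three compounds cannot be ordered. No supporting data accompany this result that could account for it.

Both the remaining hydroxy and the hydroxymethyl group are present in all three compounds, which leaves open whether the number would move if either of them were replaced as well. Also open, on these data alone, is how an amine or a carboxylic acid in place of the lost hydroxy would read in this assay, as is the reading of the shared core with a longer chain instead of a sugar on the aromatic nitrogen.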